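The source may report more compounds than this note shows. Statements on the series, on what has been measured and on what is new or still open speak of the compounds shown alone.

Measured so far in an ADME assay on liver for metabolic stability, with Liver microsome (Homo sapiens) as the target, read by LC-MS, using microsomes; on this read-out higher numbers stand for fast clearance and lower numbers for slow clearance:
- compound 1 `O=C(NCc1cc(Cl)ccc1-n1cnnn1)[C@@H]1CC=NN1C(=O)[C@H](O)c1ccccc1`: < 12 mL.min-1.g-1 (a limit of the assay, not a number)
- compound 2 `O=C(NCc1cc(Cl)ccc1-n1cnnn1)[C@@H]1C[C@@H]2C[C@@H]2N1C(=O)[C@H](O)C1CCCCC1`: 150 mL.min-1.g-1

Among the measured compounds shown here, compound 2, at 150 mL.min-1.g-1, holds the only true number so far. The only other result is the limit for compound 1. For the measured compounds named here, compound 1 and compound 2 differ in more than one place, so no single change can be read from this pair, and no measured step is available as a guide.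

The next compound is compound 3 `O=C(NCc1cc(Cl)ccc1-n1cnnn1)[C@@H]1C[C@@H]2C[C@@H]2N1C(=O)[C@H](O)Cc1ccccn1`, which keeps the core of compound 2. The change is (pyridin-2-yl)methyl in place of cyclohexyl on a saturated chain carbon bound to a carbonyl carbon and an oxygen on a saturated carbon.

With compound 2 at 150 mL.min-1.g-1, near the fast end of what has been seen, a move toward slower clearance is the more likely direction. The expected change is a 3.3-fold lower number from compound 2 to compound 3 (0.52 log units; beyond the scatter), which is expected to lie beyond the usual scatter, though with low confidence. For compound 3 the estimate is 45 mL.min-1.g-1, with an expected range of 15 mL.min-1.g-1 to 120 mL.min-1.g-1.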

Compound 3, intrinsic clearance in microsomes: 17 mL.min-1.g-1
For compound 3 the middle estimate is 2.6-fold (0.42 log units) above the measured one; measured number inside the range.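

In this assay, the step at this position, a saturated chain carbon bound to a carbonyl carbon and an oxygen on a saturated carbon, gives an 8.8-fold lower number from compound 2 to compound 3 (0.95 log units; beyond the scatter) when (pyridin-2-yl)methyl replaces cyclohexyl. Among the compounds shown here, this is the first change that can be read in one place: compound 1 and compound 2 differ in more than one place, so their pair could not tie any difference to this position, whereas here a single replacement on the shared core moves the read-out beyond the scatter. Little range remains for reading further falls in clearance as numbers: the limit of < 12 mL.min-1.g-1 in this assay, at which 1 of the 3 values shown sits.

The step replaces a non-aromatic carbon ring with an aromatic ring holding a nitrogen and also brings in the methyl link, so these parts cannot be told apart; benzyl at the same place would separate the ring nitrogen from the link, and pyridin-2-yl bound directly would test the link. Also open, going by these compounds, is how an amine or a carboxylic acid at this place would read in this assay.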